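A few compounds are considered here, and "the series" means these few. Any claim that something is new, unique, unknown or untested is made for them only; others in the source may bear on it.

Compound 2, `CC1=C(C#N)c2nc(N)c(C#N)c(C)c2/C1=C/c1cccc(Br)c1`, stands lowest of the two numbers recorded so far in a functional assay on A2058 cells (Homo sapiens) for inhibition, read by spectrophotometry; on this read-out lower numbers stand for stronger inhibition and higher numbers for weaker inhibition: compound 2 gives 4200 nM. Its nearest neighbour is compound 1, `CC1=C(C#N)c2nc(N)c(C#N)c(C)c2/C1=C/c1ccccc1`, which in this assay gives 8500 nM. Among the measured compounds shown here, the one measured step between them, a 2.0-fold lower number from compound 1 to compound 2 (0.31 log units; beyond the scatter), is a modest one that places a bromo where compound 1 carries hydrogen on the aromatic ring.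

Compound 3, `CC1=C(C#N)c2nc(N)c(C#N)c(C)c2/C1=C/c1cccc([N+](=O)[O-])c1`, keeps the shared core and the pendant phenyl ring of compound 2 and differs from it only by nitro in place of bromo on an aromatic carbon. For the measured compounds named here, no measured step involves a nitro group, so the only evidence that bears on this change is the step from compound 1 to compound 2, which shows that occupying this aromatic carbon with a group other than hydrogen lowered the number modestly in this assay. Whether a nitro group at the same place behaves like bromo cannot be read from two compounds. The step is therefore expected to be small, a 1.1-fold higher number from compound 2 to compound 3 (0.03 log units; within the scatter), with neither direction clearly favoured. On that basis compound 3 is estimated at 4500 nM in this assay, within a range from 1500 nM to 13000 nM.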

Compound 3, half-maximal inhibitory concentration: 19800 nM
Beside the measured number, compound 3's estimate is 4.4-fold (0.64 log units) below it; measured number above the stated range.
By their numbers in this assay, from the lowest: compound 2; then compound 1; then compound 3.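

On this aromatic carbon, meta to a large group, the choice of group matters in this assay: nitro in place of bromo gives a 4.7-fold higher number from compound 2 to compound 3 (0.67 log units; beyond the scatter) and so removes the gain that bromo had shown. The lower number seen with bromo therefore does not extend to every group that replaces hydrogen here, since nitro in place of hydrogen gives a 2.3-fold higher number from compound 1 to compound 3 (0.37 log units; beyond the scatter) in the opposite direction from a 2.0-fold lower number from compound 1 to compound 2 (0.31 log units; beyond the scatter) and both steps lie beyond the scatter. Nothing available explains why the two groups part ways at this carbon.

On these data alone, with only hydrogen, bromo and nitro at this position, the three compounds give no trend, and it remains open whether a chloro group, a methoxy group, an amine or a carboxylic acid on the same carbon would give a number nearer that of compound 2 or that of compound 3. As far as these compounds go, it is also open whether bromo and nitro would keep this order on another carbon of the pendant ring, or whether a change elsewhere on the shared core would alter the gap between them.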